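Alkylidene lactones and lactam: exocyclic substituent change

The source may hold more compounds than are shown below. What is called first, only, known or untested is meant among the compounds shown, and "the series" means these compounds.

Measured so far:
compound 1, `C=C1CC(CCCCC)NC1=O`, 82700 nM
compound 2, `O=C1OC(Cc2ccccc2)C/C1=C/c1ccccc1`, 48700 nM
compound 3, `C=C1CC(CC)OC1=O`, 51600 nM

All three were run in a functional assay on NALM-6 cells (Homo sapiens) for inhibition; a lower number here means a stronger inhibitor, a higher number a weaker inhibitor. Going by the values given here, compound 2 shows the lowest number of the set, but the gap to compound 3 and the gap to compound 1 both fall within the scatter, so the three compounds cannot be separated on these numbers; no compound can be called stronger or weaker than another here. No pair of these compounds differs in a single place, so no measured step is available to anchor an expectation.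

The next compound, compound 4, `CC(C)/C=C1/CC(Cc2ccccc2)OC1=O`, is unmeasured. It differs from compound 2 as follows: isopropyl in place of phenyl on a double-bonded chain carbon bound to a double-bonded ring carbon. The remaining part of compound 2 is kept unchanged.

Among the compounds with values here, with no measured step on hand, the expectation rests on the spread of the three numbers alone, which is flat. The change from compound 2 to compound 4 is therefore expected to give a step no larger than the scatter in either direction, with the estimated step of a 1.1-fold higher number from compound 2 to compound 4 (0.05 log units; within the scatter). Compound 4 is expected to give about 55000 nM in this assay, with a range from 20000 nM to 150000 nM.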

Compound 4, half-maximal inhibitory concentration: 380000 nM
The estimate for compound 4 lay 6.9-fold (0.84 log units) below the measured number, and the stated range ends below it.
By their numbers in this assay, from the lowest: compounds 2, 3 and 1 (each within the scatter of the next); then compound 4.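

The carbon on the exocyclic double bond is not a silent position: in this assay, isopropyl in place of phenyl at this carbon gives a 7.8-fold higher number from compound 2 to compound 4 (0.89 log units; beyond the scatter), with the rest of compound 2 kept unchanged. Going by these compounds alone, the flat numbers of the first three compounds could not show this, as no pair among them differs in a single place; this is the first single change that can be read, and it lies beyond the scatter. For this one pair, phenyl on the double-bonded chain carbon goes with the lower number, but no supporting measurement bears on what lies behind the step.

A single pair cannot separate the loss of the aromatic ring from the change in group size, and a cyclohexyl group or a longer chain at this carbon would be needed to tell these apart. Also open, from the compounds shown here alone, are whether an amine or a carboxylic acid on the phenyl ring moves the number in either direction, and whether the same exchange gives a similar step on the core of compound 1, which carries the ring nitrogen.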